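The compounds below may be only part of what the source reports. "The series", "measured", "known", "first", "only" and "open" are said of these compounds alone.

Compound 1 `CCOC(=O)c1ccc(-c2nn(Cc3ccccc3F)c3ccccc23)cc1` — > 10000 nM
Compound 2 `CCCOC(=O)c1ccc(-c2nn(Cc3ccccc3)c3ccccc23)cc1` — > 10000 nM
Compound 3 `CO/N=C\c1ccc(-c2nn(Cc3ccccc3)c3ccccc23)cc1` — > 10000 nM

All three compounds were tested in a functional assay on cells (Platelet, Homo sapiens) for inhibition; on this read-out higher numbers stand for weaker inhibition and lower numbers for stronger inhibition. For compound 1 the value > 10000 nM is a limit of the assay, not a number. Compound 2 likewise stops at its limit. Compound 3 stops at its own limit as well. Within the data shown here, the single step between measured compounds, a step that the two limits leave unreadable from compound 2 to compound 3, therefore cannot be read. Where compound 1 stands is known only as a limit, and the limit of > 10000 nM in this assay, at which 3 of the 3 values shown sit, covers every value shown.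

Compound 4 `CCOC(=O)c1ccc(-c2nn(-c3ccccc3)c3ccccc23)cc1` differs from compound 1 by phenyl in place of 2-fluorobenzyl on an aromatic nitrogen. Among the measured compounds shown here, no measured step touches this part of the core of compound 1; the only step in the set lies on the other outer ring and is unreadable. The data give no ground to expect a step beyond the scatter in this assay in either direction, nor to rule one out. Compound 4 is therefore estimated to give 15000 nM, most probably again only a limit, with a range from 5000 nM to 50000 nM. The expected step is a step that the limit leaves unreadable from compound 1 to compound 4.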

Compound 4, half-maximal inhibitory concentration: > 10000 nM
Compound 4 ended at the assay's limit (the forecaster's own chance of this, stated with the estimate: 85%); the middle value does not contradict the limit.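

In this assay compound 4 gives > 10000 nM and this is a limit, not a number. Among these compounds, compound 1 also stands at a limit, so no step between compound 1 and compound 4 can be read. The compounds shown leave open how far any of these changes moves inhibition, because all of them stop at the same point: the limit of > 10000 nM in this assay, at which 4 of the 4 values shown sit.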